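A few compounds are considered here, and "the series" means these few. Any claim that something is new, unique, unknown or untested is made for them only; others in the source may bear on it.

Of the compounds shown here, two have so far been tested in a functional assay on KB cells (Homo sapiens) for antiproliferative activity; a lower number here means a stronger inhibitor, a higher number a weaker inhibitor. Compound 1 `CSc1nc2cnsc2[nH]1` carries a methylsulfanyl group on the shared core and lacks the large substituent that compound 2 bears. In this assay compound 1 gives 15000 nM. Compound 2 `Cc1nsc2c1ncn2[C@H]1C[C@H](O)[C@@H](CO)O1` carries a methyl group and the large substituent but no methylsulfanyl group. In this assay compound 2 gives > 100000 nM, which is a limit of the assay rather than a measured number. Of the two values known, compound 2 sits at the limit of > 100000 nM in this assay, at which 1 of the 2 values shown sits. Compound 3 `CSc1nc2c(C)nsc2n1[C@H]1C[C@H](O)[C@@H](CO)O1` has not yet been measured; it differs from compound 2 in one place: methylsulfanyl in place of hydrogen on an aromatic carbon. For the measured compounds named here, no step between two measured compounds exists to size this change, and compound 1, which does carry a methylsulfanyl group, gives only a weak 15000 nM. Compound 3 is therefore expected to give about 60000 nM, with a likely range of 10000 nM to 200000 nM. The expected step of an at least 1.6-fold lower number from compound 2 to compound 3 (0.22 log units; that floor lies within the scatter) is a modest gain, with a fair chance that the assay again reports only a limit.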

Compound 3, half-maximal inhibitory concentration: > 100000 nM
Compound 3 was reported as a limit; the forecaster's own chance of this, stated with the estimate: 55%; middle value at least 1.6-fold (0.22 log units) from the limit.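

Compound 2 and compound 3 are both reported only as limits in this assay, so no step can be read for methylsulfanyl in place of hydrogen on an aromatic carbon: the limit of > 100000 nM in this assay, at which 2 of the 3 values shown sit.

The compounds shown leave open whether this change alters activity at all.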